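A few compounds are considered here, and "the series" means these few. Any claim that something is new, unique, unknown or untested is made for them only; others in the source may bear on it.

Working notes on the half-life of the series. In an ADME assay on the whole organism (Rattus norvegicus, strain Wistar Han) for metabolic stability, read by LC-MS, with a stated time of 7 h, at a dose of 1 mg/kg by the intravenous route (a higher number here means that the compound lasts longer, a lower number that the compound disappears faster), compound 1 `CCNC(=O)c1cc(C(=O)NC)c(=O)n(Cc2ccccc2)c1` gives 0.6 h as its read-out. Compound 2 `CNC(=O)c1cc(C(=O)NC2CC2)cn([C@H](C)c2ccccc2)c1=O` gives 0.4 h and compound 3 `CNC(=O)c1cc(C(=O)NC2CC2)cn(Cc2cccc3[nH]ccc23)c1=O` gives 0.8 h in this assay as well. Compound 3 stands within the scatter of both other compounds, so the three numbers do not separate. For the measured compounds named here, no two of them differ in one place only, and no measured step speaks directly to the next change.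

Compound 4 `CNC(=O)c1cc(C(=O)NC2CC2)cn(Cc2cccc3[nH]ncc23)c1=O` carries 1H-indazol-4-yl in place of 1H-indol-4-yl on a saturated chain carbon bound to an aromatic nitrogen and has no number yet. The expected outcome is no change at the digits printed from compound 3 to compound 4 (within the scatter) and no step beyond the scatter in either direction. This expectation rests on compound 3 at 0.8 h as the starting point and on the narrow spread of the three measured numbers. For compound 4 the estimated half-life is 0.8 h (expected range 0.4 h to 1.6 h).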

Compound 4, half-life: 0.4 h
For compound 4 the middle estimate is 2.0-fold (0.30 log units) above the measured one, and the stated range covers the measured number.
By their numbers in this assay, from the lowest: compounds 2, 4, 1 and 3 (each within the scatter of the next).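

In this assay, the series now has its first step that differs in one place only: 1H-indazol-4-yl in place of 1H-indol-4-yl on a saturated chain carbon bound to an aromatic nitrogen gives a 2.0-fold lower number from compound 3 to compound 4 (0.30 log units; within the scatter). At this place, then, a five-membered aromatic ring with 2 hetero atoms and a hydrogen-bond acceptor does not separate from the ring it replaces, although the step sits at the edge of what the scatter allows. Nothing available bears on the reason for this reading.

Still open, going by these compounds, is whether any group at this place can move the half-life beyond the scatter, for example a benzyl ring carrying a carboxylic acid or a primary amine. The compounds shown also leave open how a longer chain on either amide of the shared core would read.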